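Chloro for Fluoro on the Aryl Group of Compound 3

A few compounds are considered here, and "the series" means these few. Any claim that something is new, unique, unknown or untested is made for them only; others in the source may bear on it.

Compound 1 `Fc1ccc(-c2cn3nc(Cc4ccc(Cl)cc4)sc3n2)cc1`: in a functional assay on L1210 cells (Mus musculus) for cytotoxicity, with a stated time of 48 h (a lower number here means a stronger inhibitor, a higher number a weaker inhibitor), compound 1 gives only the limit > 250000 nM.
Compound 2 `Clc1ccc(Cc2nn3c(Br)c(-c4ccc(Cl)cc4)nc3s2)cc1`: in this assay compound 2 gives only the limit > 250000 nM.
Compound 3 `O=Cc1c(-c2ccc(F)cc2)nc2sc(Cc3ccc(Cl)cc3)nn12`: in this assay compound 3 gives 20000 nM.

Going by the values given here, compound 3 holds the only number among the three values shown. Compound 1 and compound 2 both sit at the limit of > 250000 nM in this assay, at which 2 of the 3 values shown sit. Among the compounds with values here, the one measured step, an at least 12-fold lower number from compound 1 to compound 3 (1.09 log units; beyond the scatter), is large and concerns formyl in place of hydrogen on an aromatic carbon.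

Compound 4 `O=Cc1c(-c2ccc(Cl)cc2)nc2sc(Cc3ccc(Cl)cc3)nn12` differs from compound 3 by chloro in place of fluoro on an aromatic carbon. Within the data shown here, no measured step touches this position, so the change cannot be read off any measured pair, and in this assay no step beyond the scatter is expected. Compound 4 is therefore estimated at 20000 nM, between 7000 nM and 60000 nM. This estimate means an expected step of no change at the digits printed from compound 3 to compound 4 (within the scatter).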

Compound 4, half-maximal inhibitory concentration: 15000 nM
Compound 4: the middle estimate sits 1.3-fold (0.12 log units) above what was measured, within the range that was stated.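

Chloro in place of fluoro, the first change read at this position, gives a 1.3-fold lower number from compound 3 to compound 4 (0.12 log units; within the scatter), so 4-fluorophenyl and 4-chlorophenyl cannot be told apart in this assay. The formyl group also stands out on the 4-chlorophenyl compounds, where formyl in place of bromo gives an at least 16-fold lower number from compound 2 to compound 4 (1.22 log units; beyond the scatter). Compound 2 gives only a limit of the assay, > 250000 nM.

On these data alone, whether a methoxy group at this position would move the number beyond the scatter remains open. So does whether a carboxylic acid or an amine could stand in for the formyl group.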